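Trichloromethylsulfonyl in place of ethylsulfonyl on a nitroaniline core

This account rests on a few compounds, and the source may have more. Where it says the series, first, only, none or still open, it means among the compounds named here.

Measured so far:
compound 1 `CCS(=O)(=O)c1ccc(NC2CCCCC2)c([N+](=O)[O-])c1` — > 1000000 nM
compound 2 `O=[N+]([O-])c1cc(S(=O)(=O)C(Cl)(Cl)Br)ccc1NC1CCCC1` — 93000 nM

Compound 1 `CCS(=O)(=O)c1ccc(NC2CCCCC2)c([N+](=O)[O-])c1` was tested in an assay on cells for inhibition of serine/threonine-protein kinase WNK1 (Homo sapiens), read by luminescence and Kinase-Glo, with a stated time of 2 h; a lower number here means a stronger inhibitor, a higher number a weaker inhibitor. In this assay compound 1 gives > 1000000 nM, which is a limit of the assay and not a number; it sits at the limit of > 1000000 nM in this assay, at which 1 of the 2 values shown sits. Compound 2 `O=[N+]([O-])c1cc(S(=O)(=O)C(Cl)(Cl)Br)ccc1NC1CCCC1` differs from compound 1 in more than one place, so the two values are not directly comparable; in this assay compound 2 gives 93000 nM.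

Compound 3 `O=[N+]([O-])c1cc(S(=O)(=O)C(Cl)(Cl)Cl)ccc1NC1CCCCC1` has not yet been measured. It differs from compound 1 by trichloromethyl in place of ethyl on a sulfonyl sulfur. Because compound 1 stands only at a limit > 1000000 nM, the size of the step cannot be fixed from the numbers; the change is expected to move in the direction of stronger inhibition, as the step of an at least 6.6-fold lower number from compound 1 to compound 3 (0.82 log units; beyond the scatter) expresses. Compound 3 is therefore estimated at 150000 nM, with a range from 30000 nM to 700000 nM.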

Compound 3, half-maximal inhibitory concentration: > 1000000 nM
Compound 3: a limit, no number; the forecaster's own chance of this, stated with the estimate: 25%; middle value at least 6.6-fold (0.82 log units) away from the limit.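

Compound 1 and compound 3 both stand at a limit of the assay and not at a number, so no step can be read for trichloromethyl in place of ethyl on a sulfonyl sulfur: the limit of > 1000000 nM in this assay, at which 2 of the 3 values shown sit.

The compounds shown leave open whether this change shifts inhibition at all, and by how much.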